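Methylthioether series: cytotoxicity notes toward the phenol analogue

The source may hold more compounds than are shown below. What is called first, only, known or untested is meant among the compounds shown, and "the series" means these compounds.

Measured compounds:
- compound 1 `COc1cccc(-c2cc(C)cn3c(CSCCc4ccccc4)cnc23)c1`: 100 ug/mL
- compound 2 `COc1ccc(-c2cc(C)c3ncc(CSCCc4ccccc4)n3c2)cc1`: 20 ug/mL
- compound 3 `c1ccc(CCSCc2cnc3ccc(-c4ccccc4)cn23)cc1`: 4 ug/mL

Three compounds of the series have a value in an ADME assay on HEL cells (Homo sapiens) for cytotoxicity, with a stated time of 3 days; a higher number here means that more compound is tolerated, a lower number that less compound is tolerated. Compound 1 stands at the top of the three: in this assay compound 1 gives 100 ug/mL, the highest number on record here. The nearest of the other two is compound 2, which gives 20 ug/mL, a gap beyond the usual scatter. Furthest off is compound 3, which gives 4 ug/mL, again well beyond the scatter. Both differ from compound 1 in more than one place, so the numbers are stated without any single step being assigned to them.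

Compound 4 `Cc1cc(-c2cccc(O)c2)c2ncc(CSCCc3ccccc3)n2c1` is not yet measured in this assay. It is derived from compound 1 by one change:

hydrogen in place of methyl on an oxygen on an aromatic ring

Going by the values given here, no measured pair in the set shows this change, methoxy to hydroxy, so no comparable step is available. Among the compounds with values here, with no step on record, the expectation is a step of modest size, at most at the edge of the scatter, and more likely a somewhat lower number than a higher one; the estimated step is a 1.4-fold lower number from compound 1 to compound 4 (0.15 log units; within the scatter). On that basis compound 4 is expected to give about 70 ug/mL in this assay, with a range from 20 ug/mL to 100 ug/mL.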

Compound 4, minimum cytotoxic concentration: 20 ug/mL
Estimate against measurement, compound 4: 3.5-fold (0.54 log units) above; measured number inside the range.
By their numbers in this assay, from the lowest: compound 3; then compounds 2 and 4 (each within the scatter of the next); then compound 1.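

In this assay, going by these compounds alone, the change from 3-methoxyphenyl to 3-hydroxyphenyl gives a 5.0-fold lower number from compound 1 to compound 4 (0.70 log units; beyond the scatter) and provides the only step that can be read at a single place. Within the data shown here, it shows that the methyl on this oxygen is not a silent part of compound 1: replacing that one carbon with hydrogen lowers the number by more than the usual scatter, which the earlier compounds, all differing in more than one place, could not show. The finding rests on one pair, and nothing measured here accounts for the step.

Still open, as far as these compounds go, is whether the step depends on the hydroxy group itself or simply on the loss of the methyl, a question that an ethoxy group, an amino group or a carboxylic acid in the same place would help to settle. From the compounds shown here alone, it is also open whether the same methoxy to hydroxy change would give a step of similar size and direction on compound 2, or on a core without the methyl group carried by compound 1.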